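The compounds below may be only part of what the source reports. "The series", "measured", "known", "first", "only" and "open" are said of these compounds alone.

Compound 1, `Cn1c(-c2ccccc2)nc2c(NC3CCCC3)ncnc21`: 8510 nM
Compound 2, `CCn1c(-c2ccccc2)nc2c(NC3CCC3)ncnc21`: 1440 nM

Both compounds were tested in a functional assay on CHO cells for antagonist activity at adenosine receptor A2b (Homo sapiens), read by 33P incorporation, with a stated time of 20 min; a higher number here means a weaker inhibitor, a lower number a stronger inhibitor. Compound 1 gives the higher of the two numbers, 8510 nM, and so is the weaker inhibitor of the pair. Compound 2 gives 1440 nM, a number lower than that of compound 1 by more than the usual scatter. Among the measured compounds shown here, the two differ in more than one place, so their gap cannot be tied to a single change; it shows only that a lower number is reachable.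

Compound 3, `Cn1c(-c2cccc(Cl)c2)nc2c(NC3CCCC3)ncnc21`, has not yet been measured. It differs from compound 1 in one place: chloro in place of hydrogen on an aromatic carbon. The chloro group enters on an aromatic carbon of a six-membered aromatic ring of carbon only, meta to a large group. For the measured compounds named here, no measured pair shows this change, so there is no directly comparable step to lean on, and the two measured compounds alone cannot say which way it should move the number. The expectation is a small move toward a lower number, a step of a 2.2-fold lower number from compound 1 to compound 3 (0.35 log units; beyond the scatter), close to the edge of the scatter. Compound 3 is therefore estimated at 3800 nM, with a likely range from 1200 nM to 12000 nM.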

Compound 3, inhibition constant: 2530 nM
The estimate for compound 3 lay 1.5-fold (0.18 log units) above the measured number, within the range that was stated.
By their numbers in this assay, from the lowest: compounds 2 and 3 (each within the scatter of the next); then compound 1.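

Among the compounds shown here, compound 3 gives the first direct reading of a change on the phenyl ring of this series. In this assay, chloro in place of hydrogen, on an aromatic carbon meta to a large group, gives a 3.4-fold lower number from compound 1 to compound 3 (0.53 log units; beyond the scatter). With the rest of compound 1 left unchanged, this single added chlorine atom is enough to give a modest but real step toward a stronger inhibitor, and nothing measured here offers a reason for that step.

The compounds shown leave open whether this step belongs to chloro itself or would also appear with another group in the same place, such as fluoro, methyl or methoxy, and whether chloro would give a similar step on a different carbon of the same ring. They also leave open whether the step would repeat if chloro were placed on the phenyl ring of compound 2, which differs from compound 1 in more than one place.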